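Moving the Chlorine Around the Urea Phenyl Ring

A few compounds are considered here, and "the series" means these few. Any claim that something is new, unique, unknown or untested is made for them only; others in the source may bear on it.

Of the compounds shown here, two have so far been measured in a functional assay on U-373MG ATCC cells (Homo sapiens) for inhibition, read by MTT assay, with a stated time of 72 h; on this read-out higher numbers stand for weaker inhibition and lower numbers for stronger inhibition. Compound 1 `CC1(C)CC(NC(=O)NCc2ccccc2)c2cc(Cl)ccc2O1` gives 66000 nM in this assay, while compound 2 `CC1(C)CC(NC(=O)Nc2cccc(Cl)c2)c2cc(Cl)ccc2O1` gives 21000 nM, the lower of the two numbers. Within the data shown here, the single measured step, a 3.1-fold lower number from compound 1 to compound 2 (0.50 log units; beyond the scatter), exchanges the group on the urea nitrogen. Compound 3 `CC1(C)CC(NC(=O)Nc2ccccc2Cl)c2cc(Cl)ccc2O1` keeps everything in compound 2 except that (2-chlorophenyl in place of 3-chlorophenyl on an amide-type nitrogen). Among the measured compounds shown here, no measured step exchanges a 3-chlorophenyl for a 2-chlorophenyl, so nothing here tells the direction of this change; the one step that exists speaks only to benzyl against 3-chlorophenyl and does not carry over. A step of no more than the usual scatter in this assay is therefore expected, in either direction, which for compound 3 means an estimated 25000 nM, with a likely range from 8000 nM to 80000 nM. The expected step of a 1.2-fold higher number from compound 2 to compound 3 (0.08 log units; within the scatter) is accordingly small.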

Compound 3, half-maximal inhibitory concentration: 17000 nM
Compound 3: the middle estimate sits 1.5-fold (0.17 log units) above what was measured; measured number inside the range.
By their numbers in this assay, from the lowest: compounds 3 and 2 (each within the scatter of the next); then compound 1.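

Moving the chlorine from 3-chlorophenyl to 2-chlorophenyl on the amide-type nitrogen gives a 1.2-fold lower number from compound 2 to compound 3 (0.09 log units; within the scatter) in this assay, so between these two placements the chlorine's position makes no clear difference. Compared with the benzyl group, the 2-chlorophenyl group gives a 3.9-fold lower number from compound 1 to compound 3 (0.59 log units; beyond the scatter), which shows that the advantage over benzyl seen with compound 2 also holds for compound 3. No measurement is available to explain either result.

From the compounds shown here alone, it remains open whether a phenyl ring with no chlorine at all, or one carrying a methoxy group or a nitrile instead, would give a different number. Going by these compounds, all three compounds also share the same core, including its chlorine, so the contribution of that part of the structure is untested here.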